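Replacing the 3-nitrophenyl of compound 3 with 4-methoxyphenyl

The compounds below may be only part of what the source reports. "The series", "measured", "known", "first", "only" and "open" are said of these compounds alone.

Compound 1 `CNC(=O)c1cc(Oc2ccc(C3=NNC(c4cccc(Br)c4)C3)cc2)ccn1` (1850 nM)
Compound 2 `CNC(=O)c1cc(Oc2ccc(C3=NNC(c4ccc([N+](=O)[O-])cc4)C3)cc2)ccn1` (> 50000 nM), a limit of the assay and not a number
Compound 3 `CNC(=O)c1cc(Oc2ccc(C3=NNC(c4cccc([N+](=O)[O-])c4)C3)cc2)ccn1` (26500 nM)

All three results come from a functional assay on HepG2 cells (Homo sapiens) for cytotoxicity, read by MTT assay, with a stated time of 72 h (on this read-out lower numbers stand for stronger inhibition and higher numbers for weaker inhibition), and form a very small set. Compound 3 holds the higher of the two true numbers, and compound 1 lies well under it (a 14-fold higher number from compound 1 to compound 3 (1.16 log units; beyond the scatter)). Compound 2 reports only a limit (> 50000 nM).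

Compound 4 `CNC(=O)c1cc(Oc2ccc(C3=NNC(c4ccc(OC)cc4)C3)cc2)ccn1` has not yet been measured. It differs from compound 3 by one exchange (4-methoxyphenyl in place of 3-nitrophenyl on a saturated ring carbon), with 4-methoxyphenyl in place of 3-nitrophenyl on a saturated ring carbon.

Two large steps bear on this exchange, both leading away from the 3-bromophenyl of compound 1 to a nitro-bearing group (a 14-fold higher number from compound 1 to compound 3 (1.16 log units; beyond the scatter)) and (an at least 27-fold higher number from compound 1 to compound 2 (1.43 log units; beyond the scatter)). The third step, between the two nitrophenyl groups, says little (an at least 1.8-fold lower number from compound 2 to compound 3 (0.27 log units; that floor lies within the scatter)). Within the data shown here, no measured compound carries 4-methoxyphenyl, so the size remains uncertain. Compound 4 has no nitro, so a move toward compound 1 is expected, though probably a smaller one than the full distance between compound 1 and compound 3. The expected change is a lower number (a 2.7-fold lower number from compound 3 to compound 4 (0.42 log units; beyond the scatter)). The estimate for compound 4 is a middle value (10000 nM), within an expected range (2500 nM to 40000 nM).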

Compound 4, half-maximal inhibitory concentration: 9640 nM
Beside the measured number, compound 4's estimate is 1.0-fold (0.02 log units) above it, within the range that was stated.
By their numbers in this assay, from the lowest: compound 1; then compound 4; then compound 3. At a limit, above all of these: compound 2.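

At this saturated ring carbon, in this assay, 4-methoxyphenyl carries neither nitro nor bromo and lands in the middle of the series, with a 2.7-fold lower number from compound 3 to compound 4 (0.44 log units; beyond the scatter) and a 5.2-fold higher number from compound 1 to compound 4 (0.72 log units; beyond the scatter), so dropping the nitro recovers only part of the gap to the 3-bromophenyl of compound 1. Exchanging 4-nitrophenyl for 4-methoxyphenyl gives an at least 5.1-fold lower number from compound 2 to compound 4 (0.71 log units; beyond the scatter), which shows that a group named as 4-substituted need not sit out of range, and among these four compounds the two nitro-bearing ones, compound 2 and compound 3, keep the highest readings, with none going against that. That step rests on a limit of the assay and not a number, so it gives only a floor: the limit of > 50000 nM in this assay, at which 1 of the 4 values shown sits.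

The step from compound 3 changes both the group and its place on the phenyl ring, so the compounds shown cannot separate the two, and 3-methoxyphenyl or 4-bromophenyl would be needed to do so. As far as these compounds go, whether an amine, a carboxylic acid or a longer alkoxy chain on that phenyl ring would reach or pass compound 1 also stays open.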